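Swapping the thioester of compound 3 for a methyloxazole

This account rests on a few compounds, and the source may have more. Where it says the series, first, only, none or still open, it means among the compounds named here.

Measured so far:
- compound 1, `CCCOC(=O)C1=C(C)NC(=O)NC1c1ccco1`: 3%
- compound 2, `CCNC(=O)C1=C(C)NC(=O)NC1c1ccco1`: 3%
- compound 3, `CCSC(=O)C1=C(C)NC(=O)NC1c1ccco1`: 14%

All three compounds share one core and differ only in the group attached to the carbonyl carbon. In an assay on membranes from HeLa cells for displacement of a labelled ligand from adenosine receptor A3 (Homo sapiens), read by scintillation counting, with a stated time of 180 min, tested at 1 uM (a higher number here means more inhibition at the concentration tested (going by the name of the read-out), a lower number less inhibition), compound 3 gives the highest of the three numbers; the step of a number 11 percentage points higher from compound 1 to compound 3 (beyond the scatter) and the step of a number 11 percentage points higher from compound 2 to compound 3 (beyond the scatter) are both modest, while no change at the digits printed from compound 1 to compound 2 (within the scatter) stays within the scatter. So far, then, the group on the carbonyl carbon moves the read-out only a little.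

Compound 4, `CC1=C(c2ncc(C)o2)C(c2ccco2)NC(=O)N1`, goes further: 5-methyl-1,3-oxazol-2-yl in place of (ethylsulfanyl)carbonyl on a double-bonded ring carbon. For the measured compounds named here, no measured step changes the same kind of group, since the three measured compounds all keep a carbonyl at that position; the measured steps only show that changing what hangs on that carbonyl shifts the read-out modestly at best. The expectation for compound 4 is therefore a small step of uncertain direction, with a number 2 percentage points lower from compound 3 to compound 4 (within the scatter), and in this assay compound 4 is estimated at 12%, within a range of 0% to 40%.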

Compound 4, a percentage reported as inhibition, at one concentration (the size of the read-out at that concentration, not a potency): 4%
Estimate against measurement, compound 4: 8 percentage points above; the range from low to high includes it.
By their numbers in this assay, from the lowest: compounds 1, 2, 4 and 3 (each within the scatter of the next, the first and the last beyond it).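

This is the first change that removes the carbonyl from this double-bonded ring carbon and puts an aromatic five-membered ring in its place, and in this assay it gives a number 10 percentage points lower from compound 3 to compound 4 (within the scatter), so the compounds shown do not establish that losing the (ethylsulfanyl)carbonyl group matters. The same ring also stands level with the other two carbonyl groups, with a number 1 percentage points higher from compound 2 to compound 4 (within the scatter) and a number 1 percentage points higher from compound 1 to compound 4 (within the scatter), so at this one concentration 5-methyl-1,3-oxazol-2-yl cannot be told apart from any of the three groups it is compared with, even though compound 3 alone stands beyond the scatter of compound 1 and compound 2. Nothing measured here explains this outcome.

The compounds shown leave open whether a carboxylic acid or an amine on this ring carbon, an oxazole without its methyl group, or a longer chain on the sulfur of the thioester would move the number clearly beyond the scatter. With readings at a single concentration, they also leave open how these compounds would rank across a range of concentrations.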